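Sulfonamide variation on the bicyclic octenoic acid core

This account rests on a few compounds, and the source may have more. Where it says the series, first, only, none or still open, it means among the compounds named here.

Measured so far:
compound 1 `O=C(O)CCC/C=C\C[C@H]1[C@@H]2CCC(C2)[C@@H]1NS(=O)(=O)c1ccccc1` — 1000 nM; 7400 nM; 600 nM (3 entries)
compound 2 `O=C(O)CCC/C=C\C[C@H]1[C@@H]2CCC(C2)[C@@H]1NS(=O)(=O)CCCc1ccccc1` — 14000 nM

In a functional assay (plasma) for inhibition, with Oryctolagus cuniculus as the target (a lower number here means a stronger inhibitor, a higher number a weaker inhibitor), compound 1 gives 1000 nM; 7400 nM; 600 nM (3 entries), a spread that is itself wide, as the several entries of compound 1 in this assay, 1000 nM; 7400 nM; 600 nM (3 entries) shows. Compound 2 has a single number in this assay, 14000 nM, with one further entry that gives no single number; it stands at the weak end of what has been measured, though its gap to compound 1 is no listed step and only the two sets of values can be compared.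

Compound 3 `O=C(O)CCC/C=C\C[C@H]1[C@@H]2CCC(C2)[C@@H]1NS(=O)(=O)c1ccc(C(=O)O)cc1` is not yet measured. It differs from compound 2 by 4-carboxyphenyl in place of 3-phenylpropyl on a sulfonyl sulfur. Compound 1 carries a phenyl on the same sulfonyl sulfur, and compound 3 returns to a six-membered aromatic ring of carbon only directly on that sulfur, now bearing a carboxylic acid. On that basis a step to stronger inhibition from compound 2 is expected, a 4.7-fold lower number from compound 2 to compound 3 (0.67 log units; beyond the scatter), beyond the scatter but with wide uncertainty given the spread of compound 1. Compound 3 is estimated at 3000 nM, between 500 nM and 20000 nM.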

Compound 3, half-maximal inhibitory concentration: 800000 nM
For compound 3 the middle estimate is 270-fold (2.43 log units) below the measured one; measured number above the stated range.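

In this assay the group on the sulfonyl sulfur proves able to move the number a long way: 4-carboxyphenyl in place of 3-phenylpropyl gives a 57-fold higher number from compound 2 to compound 3 (1.76 log units; beyond the scatter). The leaving and entering groups have the same heavy-atom count and each holds one six-membered aromatic ring of carbon only, so those shared counts do not predict the size of this step, and a direct aromatic ring on the sulfur does not by itself keep the number near those of compound 1. Compound 3, at 800000 nM, lies higher than every printed entry of compound 1, and even the wide spread of those entries does not reach it: the several entries of compound 1 in this assay, 1000 nM; 7400 nM; 600 nM (3 entries)

On these data alone, the step from compound 2 to compound 3 joins two changes, the loss of the propyl chain and the arrival of the carboxylic acid, so their separate shares remain unknown. A methyl ester of that acid, an amine in its place on the phenyl ring, or a benzyl group on the sulfur would help to separate them.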